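Phenyl for Methyl on the Aryl Ether of Compound 2

The source may report more compounds than this note shows. Statements on the series, on what has been measured and on what is new or still open speak of the compounds shown alone.

Measured compounds:
compound 1, `Cc1ccccc1Oc1ccc(N2C[C@@H](C(F)(F)F)C[C@H]2CC(=O)O)cc1`, 73 nM
compound 2, `Cc1ccccc1Oc1ccc(N2CCC[C@H]2CC(=O)O)cc1`, 74 nM
compound 3, `Cc1ccccc1S(=O)(=O)c1ccc(N2CCC[C@H]2CC(=O)O)cc1`, reported only as a limit

In a functional assay on cells for agonist activity at Free fatty acid receptor 1 (Homo sapiens), read by FLIPR and calcium flux, with a stated time of 100 s (a lower number here means that less compound is needed, a higher number that more compound is needed for the effect), compound 2 gives 74 nM, which is the highest of the two numbers shown; its nearest neighbour is compound 1, and the step of a 1.0-fold higher number from compound 1 to compound 2 (0.01 log units; within the scatter) lies within the scatter. For compound 3 the read-out is a limit, > 33000 nM, and not a number; this is recorded in the limit of > 33000 nM in this assay, at which 1 of the 3 values shown sits.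

Compound 4, `O=C(O)C[C@@H]1CCCN1c1ccc(Oc2ccccc2-c2ccccc2)cc1`, differs from compound 2 in one place: phenyl in place of methyl on an aromatic carbon.

For the measured compounds named here, no measured step touches the group sitting on the aryl ether; the only step measured, from compound 1 to compound 2, concerns the saturated ring and was within the scatter. Going by the values given here, there is therefore no measured step that bears on the change to compound 4. The expectation for compound 4 in this assay is a step of a 2.0-fold higher number from compound 2 to compound 4 (0.31 log units; beyond the scatter), a modest movement that may not go beyond the scatter, with the estimate for compound 4 at 150 nM in the range 40 nM to 600 nM.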

Compound 4, half-maximal effective concentration: 3500 nM
Compound 4: middle estimate off by 23-fold (1.37 log units), on the low side; measured number outside the range, above it.
By their numbers in this assay, from the lowest: compounds 1 and 2 (each within the scatter of the next); then compound 4. At a limit, above all of these: compound 3.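

For the compounds shown here, this is the first measured change at the aromatic carbon ortho to a large group, and in this assay that position proves sensitive, with a 47-fold higher number from compound 2 to compound 4 (1.67 log units; beyond the scatter) for the exchange of methyl for phenyl. Going by these compounds alone, the only earlier step, a 1.0-fold higher number from compound 1 to compound 2 (0.01 log units; within the scatter) on a saturated ring carbon, lay within the scatter and so gave no sign that the aromatic position would respond in this way. Phenyl lowers the response here without abolishing it, as compound 4 still gives a measured number of 3500 nM in this assay.

Nothing measured here gives a cause for this step. Still open, going by these compounds, is how a fluorine, a methoxy group or a pyridyl ring would fare at this place, and whether a group of intermediate size, such as ethyl, would sit closer to methyl or to phenyl.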